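Swapping 3-nitrophenyl for 1-methylpiperidin-4-yl on a carbonyl carbon

This account rests on a few compounds, and the source may have more. Where it says the series, first, only, none or still open, it means among the compounds named here.

Compound 1 `O=C(Nc1ccccn1)c1cccc(Nc2ncc(F)c(Nc3ccc(F)cc3)n2)c1` gives 13700 nM
Compound 2 `O=C(c1cccc(Nc2ncc(F)c(Nc3ccc(F)cc3)n2)c1)N1CCCCC1` gives 13800 nM
Compound 3 `O=C(Nc1cccc(Nc2ncc(F)c(Nc3ccc(F)cc3)n2)c1)c1cccc([N+](=O)[O-])c1` gives 11400 nM

These three values come from a functional assay on KBVIN cells (Homo sapiens) for antiproliferative activity, read by sulforhodamine B assay, with a stated time of 3 days (a higher number here means a weaker inhibitor of growth, a lower number a stronger inhibitor of growth), and they sit close together. Compound 3, at 11400 nM, lies within the scatter of both compound 1 and compound 2, so it stands level with them and no order can be drawn among the three.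

Compound 4 `CN1CCC(C(=O)Nc2cccc(Nc3ncc(F)c(Nc4ccc(F)cc4)n3)c2)CC1` differs from compound 3 by 1-methylpiperidin-4-yl in place of 3-nitrophenyl on a carbonyl carbon and the rest of the structure stays the same. In words, 1-methylpiperidin-4-yl takes the place of 3-nitrophenyl on a carbonyl carbon, so a six-membered aromatic ring of carbon only gives way to a six-membered non-aromatic ring with one hetero atom.

Within the data shown here, only one measured step bears on this, and only loosely. The step of a 1.0-fold higher number from compound 1 to compound 2 (0.00 log units; within the scatter) also puts a non-aromatic ring on a carbonyl carbon, with piperidin-1-yl replacing (pyridin-2-yl)amino, and it stayed within the scatter. Among the measured compounds shown here, no measured compound other than compound 3 carries 3-nitrophenyl, and none carries 1-methylpiperidin-4-yl, so the direct test is missing. No shift beyond the scatter is therefore expected, and neither direction is favoured. The estimated change is a 1.0-fold lower number from compound 3 to compound 4 (0.02 log units; within the scatter) in this assay and would stay within the scatter. Compound 4 is expected at 11000 nM, with an estimated range of 4500 nM to 22000 nM.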

Compound 4, concentration for 50% growth inhibition: 11900 nM
Beside the measured number, compound 4's estimate is 1.1-fold (0.03 log units) below it; the range from low to high includes it.
By their numbers in this assay, from the lowest: compounds 3, 4, 1 and 2 (each within the scatter of the next).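

In this assay, among these compounds, the exchange on the carbonyl carbon, whose other neighbour is an amide-type nitrogen, gave a 1.0-fold higher number from compound 3 to compound 4 (0.02 log units; within the scatter), so the one aromatic group on this carbonyl and a six-membered non-aromatic ring with one hetero atom could not be told apart at this position. The wider comparisons read the same way: the ((1-methylpiperidin-4-yl)carbonyl)amino group gave a 1.2-fold lower number from compound 2 to compound 4 (0.06 log units; within the scatter) when it stood in place of (piperidin-1-yl)carbonyl, and a 1.2-fold lower number from compound 1 to compound 4 (0.06 log units; within the scatter) when it stood in place of (pyridin-2-yl)carbamoyl, so none of these substituents on the aromatic carbon separates from the others in this series. No measurement at hand offers an explanation for this flat result.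

With every step inside the scatter, the compounds shown do not reveal which kind of group, if any, would shift the number at this carbonyl carbon. A carboxylic acid, a primary amine or a longer alkyl chain in place of 1-methylpiperidin-4-yl could be set against compound 4 to test whether the position responds to change at all.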